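A Change of Configuration at Two Ring Stereocentres

The source may hold more compounds than are shown below. What is called first, only, known or untested is meant among the compounds shown, and "the series" means these compounds.

Compound 1 `COc1cccc(CN2C(=O)C(C3=NS(=O)(=O)c4cc(NS(C)(=O)=O)ccc4N3)=C(O)[C@@H]3[C@H]4CC[C@H](C4)[C@@H]32)c1` half-life > 1 h (a limit)
Compound 2 `CC(C)CCN1C(=O)C(C2=NS(=O)(=O)c3cc(NS(C)(=O)=O)ccc3N2)=C(O)[C@@H]2[C@H]3CC[C@H](C3)[C@@H]21` half-life 0.617 h
Compound 3 `CS(=O)(=O)Nc1ccc2c(c1)S(=O)(=O)N=C(C1=C(O)[C@@H]3[C@H]4CC[C@H](C4)[C@@H]3N(CC3CCCCC3)C1=O)N2` half-life 0.733 h

All three compounds were tested in an in vitro ADME assay on microsomes from liver (Homo sapiens) for metabolic stability, tested at 1 uM (a lower number here means that the compound disappears faster, a higher number that the compound lasts longer), and differ only in the group on the saturated chain carbon bound to an amide-type nitrogen in a ring. Compound 1 gives > 1 h as a limit of the assay and not a number. On these data alone, its standing is therefore the limit of > 1 h in this assay, at which 1 of the 3 values shown sits, and its exact half-life is unknown.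

Compound 4 `COc1cccc(CN2C(=O)C(C3=NS(=O)(=O)c4cc(NS(C)(=O)=O)ccc4N3)=C(O)[C@@H]3[C@@H]4CC[C@@H](C4)[C@@H]32)c1` has the atoms and bonds of compound 1 and differs in configuration alone, as the two compounds have the same atoms and bonds and differ only in configuration as drawn: 2 of 4 stereo elements differ; a stereocentre at a saturated ring carbon is drawn S in compound 1 and R in compound 4; a stereocentre at a saturated ring carbon is drawn R in compound 1 and S in compound 4 shows in full. For the measured compounds named here, no measured step touches configuration. The nearest evidence comes from the side-group changes, namely an at least 1.6-fold lower number from compound 1 to compound 2 (0.20 log units; that floor lies within the scatter) and an at least 1.3-fold lower number from compound 1 to compound 3 (0.13 log units; that floor lies within the scatter) as well as a 1.2-fold higher number from compound 2 to compound 3 (0.07 log units; within the scatter) in the last pair. All three lie within the scatter, and the first two are only floors. They concern a different kind of change and give no direction for the new compound, so no step beyond the scatter is expected. The expected change is a number no higher from compound 1 to compound 4 (the limit leaves the size open) on this estimate. For compound 4 the estimated half-life is 1 h with an expected range from 0.5 h to 1.8 h in this assay and a real chance of another limit.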

Compound 4, half-life: > 1 h
Compound 4 gave a limit, no number; the forecaster's own chance of this, stated with the estimate: 40%; the middle value lies on the limit itself.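

In this assay, for the compounds shown here, compound 1 and compound 4 both end at a limit and give no number, so no step between them can be read: the limit of > 1 h in this assay, at which 2 of the 4 values shown sit. The compounds shown leave open whether the change at the two ring stereocentres alters the half-life at all, as the only difference in this pair is: the fact that compounds 1 and 4 differ only in the configuration as drawn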